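The source may report more compounds than this note shows. Statements on the series, on what has been measured and on what is new or still open speak of the compounds shown alone.

Compound 1 `Nc1nc(N)c2c(-c3ccccc3)cn([C@@H]3O[C@H](CO)[C@@H](O)[C@H]3O)c2n1` carries a phenyl group on a fused two-ring core that bears a sugar. Compound 2 `CNc1ncnc2c1c(-c1ccccc1)cn2[C@@H]1O[C@H](CO)[C@@H](O)[C@H]1O` rests on a related core; how the two cores differ is not broken down here. Compound 3 `CNc1ncnc2c1c(-c1cccs1)cn2[C@@H]1O[C@H](CO)[C@@H](O)[C@H]1O` shares the core of compound 2.

In a functional assay on CCRF-CEM cells (Homo sapiens), read by MTT assay, with a stated time of 72 h (on this read-out higher numbers stand for weaker inhibition and lower numbers for stronger inhibition), compound 1 gives > 20000 nM, which is a limit of the assay rather than a number. Compound 2 gives > 20000 nM in this assay, again a limit. Compound 3 gives > 20000 nM in this assay, also a limit.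

The change from compound 2 to compound 3 is thiophen-2-yl in place of phenyl on an aromatic carbon. The size of this step is a step that the two limits leave unreadable from compound 2 to compound 3, because the limit of > 20000 nM in this assay, at which 3 of the 3 values shown sit, leaves no distance to read between the two.

Compound 4 `Nc1nc(N)c2c(-c3cccs3)cn([C@@H]3O[C@H](CO)[C@@H](O)[C@H]3O)c2n1` has not yet been measured in this assay. Among the measured compounds shown here, it differs from compound 1 by thiophen-2-yl in place of phenyl on an aromatic carbon, which is the same change at the same place as the one from compound 2 to compound 3.

Since that earlier step could not be sized, the expected step that the limit leaves unreadable from compound 1 to compound 4 rests only on the fact that compound 1 sits at > 20000 nM and on compound 2 and compound 3 both sitting at the limit after the same change. For compound 4 the estimate is 30000 nM, with an expected range from 8000 nM to 100000 nM, and most likely the assay will again report only a limit.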

Compound 4, half-maximal inhibitory concentration: > 20000 nM
Compound 4: only a limit was reported; the forecaster's own chance of this, stated with the estimate: 85%; the middle value is on the limit's open side.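

In this assay compound 4 gives > 20000 nM, which is a limit and not a number. No size can be read for the change from phenyl in compound 1 to thiophen-2-yl in compound 4, because both compounds sit at the same limit: the limit of > 20000 nM in this assay, at which 4 of the 4 values shown sit.

The compounds shown leave open how strongly any of them inhibits, and whether phenyl or thiophen-2-yl gives the stronger inhibition on either core.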